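Adding a Piperazine Arm to an Inactive Oxadiazole

The source may report more compounds than this note shows. Statements on the series, on what has been measured and on what is new or still open speak of the compounds shown alone.

Measured compounds:
compound 1 `Cc1ccc(-c2cn(-c3ccc(CN4CCN(C)CC4)c(C(F)(F)F)c3)nn2)cc1Nc1nccc(-c2cccnc2)n1` — 1040 nM
compound 2 `CCN(CC)c1ccc(-n2cc(-c3ccc(C)c(Nc4nccc(-c5cccnc5)n4)c3)nn2)cc1` — 2930 nM
compound 3 `Cc1ccc(-c2nnc(-c3ccc(C)c(C(F)(F)F)c3)o2)cc1Nc1nccc(-c2cccnc2)n1` — > 30000 nM

All three were tested in a functional assay on KG-1a cells (Homo sapiens) for inhibition, read by MTT assay, with a stated time of 72 h; a higher number here means a weaker inhibitor, a lower number a stronger inhibitor. Compound 1 gives 1040 nM and compound 2 gives 2930 nM. For compound 3 this assay reports no number, only a limit of > 30000 nM; that limit, (the limit of > 30000 nM in this assay, at which 1 of the 3 values shown sits), is the weakest outcome the measurement can report, so compound 3 stands at the bottom of the three on the numbers shown.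

Compound 4 `Cc1ccc(-c2nnc(-c3ccc(CN4CCN(CCN=C=S)CC4)c(C(F)(F)F)c3)o2)cc1Nc1nccc(-c2cccnc2)n1` is built from compound 3 by one change: a group of 11 heavy atoms (7 carbon, 3 nitrogen, 1 sulfur; one six-membered non-aromatic ring with 2 hetero atoms) in place of a hydrogen atom, on a saturated chain carbon bound to an aromatic carbon. Within the data shown here, no measured pair in this set shares exactly this change, so the size of the step rests on expectation alone. Compound 1 carries a related six-membered ring on the same kind of chain carbon and gives 1040 nM, which supports an expected move toward stronger inhibition in this assay, estimated as an at least 3.3-fold lower number from compound 3 to compound 4 (0.52 log units; beyond the scatter) for the step from compound 3 to compound 4. Compound 4 is therefore estimated at 9000 nM, with a range from 2000 nM to 30000 nM.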

Compound 4, half-maximal inhibitory concentration: 940 nM
For compound 4 the middle estimate is 9.6-fold (0.98 log units) above the measured one; the measured number lies below the stated range.
By their numbers in this assay, from the lowest: compounds 4 and 1 (each within the scatter of the next); then compound 2. At a limit, above all of these: compound 3.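

In this assay, this saturated chain carbon bound to an aromatic carbon accepts a large group, and the change gives an at least 31-fold lower number from compound 3 to compound 4 (1.50 log units; beyond the scatter). Until now, the core of compound 3 with only a hydrogen atom at this place had offered no number to compare, so nothing showed whether a substituent here could bring inhibition into the measurable range. The true size of the step remains unknown, since compound 3 gives only a limit: the limit of > 30000 nM in this assay, at which 1 of the 4 values shown sits.

The entering group holds both a six-membered non-aromatic ring and an isothiocyanate, and the compounds shown do not tell which part carries the step. A simple amine or a morpholine ring at this place on the same core would help to separate the two contributions.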